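Pyridin-3-yl in Place of Phenyl on the Saturated Carbon

A few compounds are considered here, and "the series" means these few. Any claim that something is new, unique, unknown or untested is made for them only; others in the source may bear on it.

Compound 3 `OCc1cn2c(c1CO)CS[C@@H]2c1ccccc1` stands highest of the three compounds measured in a functional assay on MCF7 cells (Homo sapiens) for cytotoxicity, read by MTT assay, with a stated time of 48 h (a higher number here means a weaker inhibitor, a lower number a stronger inhibitor), where compound 3 gives 19400 nM. Compound 1 `Cc1c(COC(=O)NCc2ccccc2)cc2n1[C@@H](c1ccccc1)SC2` gives 4400 nM in this assay, and compound 2 `Cc1c(CO)c(CO)c2n1[C@@H](c1ccccc1)SC2` gives 1900 nM. Going by the values given here, the only step between measured compounds that differ in one place, a 10-fold higher number from compound 2 to compound 3 (1.01 log units; beyond the scatter), concerns a different part of the shared core. Compound 4 `OCc1cn2c(c1CO)CS[C@@H]2c1cccnc1` differs from compound 3 in one place: pyridin-3-yl in place of phenyl on a saturated ring carbon. Among the compounds with values here, no measured step touches this part of the structure, so for compound 4 in this assay no step beyond the scatter is expected in either direction. Compound 4 is therefore estimated at 20000 nM, with a range from 8000 nM to 50000 nM, so that a 1.0-fold higher number from compound 3 to compound 4 (0.01 log units; within the scatter) is the expected step.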

Compound 4, half-maximal inhibitory concentration: 128000 nM
The estimate for compound 4 lay 6.4-fold (0.81 log units) below the measured number; measured number above the stated range.
By their numbers in this assay, from the lowest: compound 2; then compound 1; then compound 3; then compound 4.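

Going by these compounds alone, the saturated ring carbon, which no earlier step touched, responds to change in this assay: pyridin-3-yl in place of phenyl gives a 6.6-fold higher number from compound 3 to compound 4 (0.82 log units; beyond the scatter). With the heavy-atom count unchanged, replacing one ring carbon of this aromatic group with nitrogen is enough to weaken the compound beyond the scatter. No measurement at hand accounts for this step.

The compounds shown leave open whether pyridin-2-yl or pyridin-4-yl on this carbon would match pyridin-3-yl. They also leave open whether the same exchange would cost as much with the methyl group of compound 2 present.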